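A few compounds are considered here, and "the series" means these few. Any claim that something is new, unique, unknown or untested is made for them only; others in the source may bear on it.

Three compounds have been measured in a functional assay on NCI/ADR-RES cells (Homo sapiens) for antiproliferative activity, with a stated time of 48 h; on this read-out lower numbers stand for stronger inhibition of growth and higher numbers for weaker inhibition of growth:

Compound 1, `Cc1cc(O)c(C2=NN(c3ccc(S(N)(=O)=O)cc3)C(c3ccccc3O)C2)cc1Cl`, gives 14100 nM.
Compound 2, `Cc1cc(O)c(C2=NN(c3ccc(S(N)(=O)=O)cc3)C(c3ccccc3Cl)C2)cc1Cl`, gives 6850 nM.
Compound 3, `Cc1cc(O)c(C2=NN(c3ccc(S(N)(=O)=O)cc3)C(/C=C/c3ccccc3)C2)cc1Cl`, gives 22700 nM.

Compound 3 carries the highest number of the three. Its gap to compound 2 lies beyond the scatter (a 3.3-fold higher number from compound 2 to compound 3 (0.52 log units; beyond the scatter)), whereas its gap to compound 1 lies within the scatter (a 1.6-fold higher number from compound 1 to compound 3 (0.21 log units; within the scatter)), so no order between compound 1 and compound 3 can be read from these numbers.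

Compound 4, `COc1ccc(C2CC(c3cc(Cl)c(C)cc3O)=NN2c2ccc(S(N)(=O)=O)cc2)cc1OC`, differs from compound 3 in one place: 3,4-dimethoxyphenyl in place of 2-phenylethenyl on a saturated ring carbon. The two measured steps that bear on this change are those in which an aromatic ring on the same saturated ring carbon was exchanged for 2-phenylethenyl, namely a 1.6-fold higher number from compound 1 to compound 3 (0.21 log units; within the scatter) and a 3.3-fold higher number from compound 2 to compound 3 (0.52 log units; beyond the scatter). Both moved the number upward, one within and one beyond the scatter. Compound 4 reverses that kind of exchange, putting an aromatic ring back in place of 2-phenylethenyl, though its ring carries methoxy groups that neither compound 1 nor compound 2 has, and nothing measured shows how such groups behave here. A modest downward step is therefore expected, a 2.3-fold lower number from compound 3 to compound 4 (0.36 log units; beyond the scatter), landing between the numbers of compound 1 and compound 2. Compound 4 is estimated at 10000 nM, with a range from 4000 nM to 25000 nM.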

Compound 4, concentration for total growth inhibition: 14100 nM
Compound 4: the middle estimate sits 1.4-fold (0.15 log units) below what was measured, within the range that was stated.
By their numbers in this assay, from the lowest: compound 2; then compounds 1, 4 and 3 (each within the scatter of the next).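

In this assay, the saturated ring carbon now carries a third aromatic ring, and 3,4-dimethoxyphenyl gives the same reading as 2-hydroxyphenyl (no change at the digits printed from compound 1 to compound 4 (within the scatter)) and cannot be told apart from 2-phenylethenyl (a 1.6-fold lower number from compound 3 to compound 4 (0.21 log units; within the scatter)). Having an aromatic ring on this carbon therefore does not by itself set a compound apart from compound 3, since among the three ring-bearing compounds only compound 2 has a step from compound 3 beyond the scatter, while compound 1 and compound 4 do not; 2-chlorophenyl also remains separated from 3,4-dimethoxyphenyl (a 2.1-fold higher number from compound 2 to compound 4 (0.31 log units; beyond the scatter)). No measurement offered here explains why 2-chlorophenyl stands apart.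

The compounds shown leave open whether the chloro group itself accounts for that separation, and whether a single methoxy group would read differently from the pair. They also do not show how this carbon responds to a group of another kind, such as a phenyl ring bearing an amine or a carboxylic acid, or a longer saturated chain.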